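This account rests on a few compounds, and the source may have more. Where it says the series, first, only, none or still open, it means among the compounds named here.

The measured compounds:

Compound 1, `Cc1ccccc1Cn1ccc2nc(-c3ccccc3)nc-2c1`: in an ADME assay on MDBK cells (Bos taurus) for cytotoxicity (on this read-out higher numbers stand for lower toxicity in this test and lower numbers for higher toxicity in this test), compound 1 gives > 100000 nM, which is a limit of the assay and not a number.
Compound 2, `Brc1ccc(Cn2ccc3nc(-c4ccccc4)nc-3c2)cc1`: in this assay compound 2 gives 83000 nM.
Compound 3, `N#Cc1ccccc1Cn1ccc2nc(-c3ccccc3)nc-2c1`: in this assay compound 3 gives > 100000 nM, again a limit of the assay rather than a number.

Compound 3 therefore stands at the limit of > 100000 nM in this assay, at which 2 of the 3 values shown sit, so only a floor of low toxicity is known for it, not a point. The step to compound 4, `CCn1ccc2nc(-c3ccccc3)nc-2c1`, is methyl in place of 2-cyanophenyl on a saturated chain carbon bound to an aromatic nitrogen. Among the measured compounds shown here, two measured steps touch this region of the molecule: an at least 1.2-fold lower number from compound 1 to compound 2 (0.08 log units; that floor lies within the scatter) and an at least 1.2-fold higher number from compound 2 to compound 3 (0.08 log units; that floor lies within the scatter), both of them small and bounded only from one side, and a step that the two limits leave unreadable from compound 1 to compound 3, which cannot be read because both ends are limits. None of the three swaps on the saturated chain carbon bound to an aromatic nitrogen has moved the read-out beyond the scatter. Shrinking the group there to methyl is expected to leave compound 4 near the same floor, so a number no higher from compound 3 to compound 4 (the limit leaves the size open) is the expected outcome. Compound 4 is estimated at 100000 nM, with a range from 40000 nM to 300000 nM.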

Compound 4, half-maximal cytotoxic concentration: > 100000 nM
Compound 4: no number, only a limit (the forecaster's own chance of this, stated with the estimate: 60%); the middle value sits exactly at the limit.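

Earlier swaps at this place only exchanged one substituted phenyl group for another, whereas here the whole six-membered aromatic ring leaves, and in this assay compound 4 still gives > 100000 nM, which is a limit of the assay and not a number. So a group of this size on the saturated chain carbon bound to an aromatic nitrogen is not needed to keep the read-out at this low-toxicity limit, and the only readable change is an at least 1.2-fold higher number from compound 2 to compound 4 (0.08 log units; that floor lies within the scatter). The steps from compound 1 and from compound 3 to compound 4 have limits at both ends and cannot be read, so the series gathers at one ceiling: the limit of > 100000 nM in this assay, at which 3 of the 4 values shown sit.

How far these compounds really differ stays hidden behind that limit, and only compound 2 has an actual number. Going by these compounds, whether an amine, a carboxylic acid or a longer chain at this place would bring the read-out down to a clear number stays open, as does the effect of any change on the shared core.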